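A few compounds are considered here, and "the series" means these few. Any claim that something is new, unique, unknown or untested is made for them only; others in the source may bear on it.

Measured compounds:
- compound 1 `O=C(Nc1cccc(-c2oc3cc(-c4ccc(F)cc4)ccc3c(=O)c2O)c1)c1ccc(F)cc1F`: 13500 nM in a functional assay on MCF7 cells (Homo sapiens) for antiproliferative activity, read by CCK-8 assay, with a stated time of 72 h; a lower number here means a stronger inhibitor, a higher number a weaker inhibitor
- compound 2 `Cc1ccccc1C(=O)Nc1cccc(-c2oc3cc(-c4ccc(F)cc4)ccc3c(=O)c2O)c1`: 2280 nM in this assay
- compound 3 `O=C(Nc1cccc(-c2oc3cc(-c4ccc(F)cc4)ccc3c(=O)c2O)c1)c1ccc(Br)cc1`: 24000 nM in this assay

Compound 3 gives the highest number of the three. Its gap to compound 1, a 1.8-fold higher number from compound 1 to compound 3 (0.25 log units; within the scatter), lies within the scatter, whereas an 11-fold higher number from compound 2 to compound 3 (1.02 log units; beyond the scatter) is a large step beyond it. Compound 4 `Cc1cc(C)cc(C(=O)Nc2cccc(-c3oc4cc(-c5ccc(F)cc5)ccc4c(=O)c3O)c2)c1` carries 3,5-dimethylphenyl in place of 4-bromophenyl on a carbonyl carbon. Among the compounds with values here, the step that bears on this is the one from compound 2 to compound 3, where a methyl-bearing phenyl sat in place of the bromophenyl and the number was far lower. Because an 11-fold higher number from compound 2 to compound 3 (1.02 log units; beyond the scatter) is large, compound 4 is expected to give a lower number than compound 3 in this assay, though 2-methylphenyl and 3,5-dimethylphenyl are not the same group, so a smaller step is assumed. Compound 4 is estimated at 6000 nM (range 2000 nM to 20000 nM), that is a 4.0-fold lower number from compound 3 to compound 4 (0.60 log units; beyond the scatter).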

Compound 4, half-maximal inhibitory concentration: 20400 nM
The estimate for compound 4 lay 3.4-fold (0.53 log units) below the measured number; measured number above the stated range.
By their numbers in this assay, from the lowest: compound 2; then compounds 1, 4 and 3 (each within the scatter of the next).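

In this assay, 3,5-dimethylphenyl on the carbonyl carbon does not reproduce the low number of the 2-methylphenyl amide (an 8.9-fold higher number from compound 2 to compound 4 (0.95 log units; beyond the scatter)). Carrying methyl groups is therefore not enough at this position: compound 4 stays level with the halogen-bearing amides (a 1.2-fold lower number from compound 3 to compound 4 (0.07 log units; within the scatter); a 1.5-fold higher number from compound 1 to compound 4 (0.18 log units; within the scatter)), and among these four only compound 2 stands apart. Open, from the compounds shown here alone, is whether a phenyl bearing a methoxy group or an amine, or a non-aromatic group such as a longer chain, would reach the number of compound 2 or go lower. No measurement on these compounds gives a reason for the gap.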